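Taking one ester off compound 1

This account rests on a few compounds, and the source may have more. Where it says the series, first, only, none or still open, it means among the compounds named here.

Compound 1 `CCCC(CCC)C(=O)OC[C@H]1O[C@@H](n2cnc3c(N)ncnc32)[C@H](OC(=O)C(CCC)CCC)[C@]1(C)O`: 54400 nM
Compound 2 `CCCC(CCC)C(=O)O[C@H]1[C@H](n2cnc3c(N)ncnc32)O[C@H](CO)[C@@]1(C)O`: > 1000000 nM
Compound 3 `CCCC(CCC)C(=O)Nc1ncnc2c1ncn2[C@@H]1O[C@H](COC(=O)C(CCC)CCC)[C@@](C)(O)[C@H]1OC(=O)C(CCC)CCC`: "nd(insoluble)" (no result reported)

Among the measured compounds shown here, in a functional assay on HeLa cells (Homo sapiens) for inhibition, read by MTT assay, with a stated time of 48 h (on this read-out higher numbers stand for weaker inhibition and lower numbers for stronger inhibition), compound 1 gives 54400 nM, the only exact number in this small set. For compound 2 the entry is > 1000000 nM, which is a limit of the assay and not a number. Compound 3 has no numerical result, and its entry reads "nd(insoluble)" (no result reported).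

Compound 1 carries two (1-propylbutyl)carbonyl groups, each on an oxygen. Compound 4 `CCCC(CCC)C(=O)OC[C@H]1O[C@@H](n2cnc3c(N)ncnc32)[C@H](O)[C@]1(C)O` keeps one of them and loses the other: hydrogen in place of (1-propylbutyl)carbonyl on an oxygen on a saturated carbon. Put simply, ((1-propylbutyl)carbonyl)oxy becomes hydroxy, on a saturated carbon whose other neighbours are saturated ring carbon.

For the measured compounds named here, only one measured step bears on this change: an at least 18-fold higher number from compound 1 to compound 2 (1.26 log units; beyond the scatter). That step is large, but it removes the other (1-propylbutyl)carbonyl group, so it is a guide rather than a direct precedent. Its true size is also unknown, since it ends at the limit of > 1000000 nM in this assay, at which 1 of the 3 values shown sits. Given that single step, weaker inhibition is expected here too, probably by a smaller margin, though this is uncertain. The estimated change is a 3.7-fold higher number from compound 1 to compound 4 (0.57 log units; beyond the scatter). For compound 4 the expected value is 200000 nM, with an estimated range of 50000 nM to 800000 nM.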

Compound 4, half-maximal inhibitory concentration: > 200000 nM
Compound 4 was reported as a limit; the forecaster's own chance of this, stated with the estimate: 30%; the middle value sits exactly at the limit.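

The earlier step took away one of the two (1-propylbutyl)carbonyl groups of compound 1; this step takes away the other, and in this assay it gives an at least 3.6-fold higher number from compound 1 to compound 4 (0.56 log units; beyond the scatter) in the direction of weaker inhibition. Among the compounds shown, then, losing either ester weakens inhibition, so this position is not a spare one, and hydroxy here does not stand in for ((1-propylbutyl)carbonyl)oxy. Compound 4 is reported only as a limit of the assay and not as a number, so this step has a floor but no known upper end: the limit of > 200000 nM in this assay, at which 1 of the 4 values shown sits.

Compound 2 and compound 4 both end at limits and differ from each other in more than one place, so the compounds shown cannot tell which of the two esters counts for more. They also leave open how this oxygen would behave with a different acyl group, such as a small acetyl or a flat benzoyl, and whether an amine in place of the hydroxy would recover any of the lost inhibition.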